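Methoxy in place of amino on the aminophenyl ring

The source may hold more compounds than are shown below. What is called first, only, known or untested is meant among the compounds shown, and "the series" means these compounds.

This account follows the step from compound 1 to compound 3. Compound 1 `COc1cc(-c2cc(/C=C/C(=O)c3ccc(N)cc3)[nH]n2)cc(OC)c1OC` is the lower of the two numbers shown: in a functional assay on NCI-H460 cells (Homo sapiens) for cytotoxicity, read by sulforhodamine B assay, with a stated time of 48 h, tested at 1 uM (a lower number here means a stronger effect, a higher number a weaker effect of the compound at the concentration tested), compound 1 gives 78%, while compound 2 `COc1ccc(-c2cc(/C=C/C(=O)c3ccc(N)cc3)[nH]n2)cc1OC` gives 94%. Going by the values given here, the one step so far, a number 16 percentage points higher from compound 1 to compound 2 (beyond the scatter), arises from hydrogen in place of methoxy on an aromatic carbon.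

Compound 3 `COc1ccc(C(=O)/C=C/c2cc(-c3cc(OC)c(OC)c(OC)c3)n[nH]2)cc1` differs from compound 1 at a different place: methoxy in place of amino on an aromatic carbon. Among the compounds with values here, no measured step touches this position, so the step to compound 2 gives no direct guide to the size or direction of the change, and it only shows that an alteration of a single group on one ring can move this assay by a modest amount beyond the scatter. Within the data shown here, with no closer precedent, the expectation for compound 3 is a step of a number 7 percentage points higher from compound 1 to compound 3 (within the scatter), which may fall within the scatter or lean toward a weaker effect. Compound 3 is therefore estimated at 85%, with a range from 65% to 100%.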

Compound 3, a percentage reported as activity, at one concentration (the size of the read-out at that concentration, not a potency): 85%
Beside the measured number, compound 3's estimate shows no gap at the digits printed; the range from low to high includes it.
By their numbers in this assay, from the lowest: compounds 1, 3 and 2 (each within the scatter of the next, the first and the last beyond it).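

Methoxy in place of amino on the aromatic carbon para to a large group gives, in this assay, a number 7 percentage points higher from compound 1 to compound 3 (within the scatter), so this assay does not separate the two compounds. This is the first reading at this position, and it shows that the amino group of compound 1, with its hydrogen-bond donor, can give way to methoxy, which counts none, without a change beyond the scatter; the earlier step, a number 16 percentage points higher from compound 1 to compound 2 (beyond the scatter), lay on the other aryl ring and went beyond the scatter, so the two positions do not answer alike to the single changes shown here. Nothing at hand accounts for this tolerance at the level of mechanism, and the result stands as an observation only.

Going by these compounds, whether a hydroxyl group, a dimethylamino group or a chlorine atom at this position would also stay within the scatter of compound 1 remains open, as does whether methoxy in place of amino would read the same on the core of compound 2. The read-out is also taken at one concentration, so any difference in potency between compound 1 and compound 3 is left undetermined.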